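Two Chlorines Replace a Methyl on the Urea Phenyl

A few compounds are considered here, and "the series" means these few. Any claim that something is new, unique, unknown or untested is made for them only; others in the source may bear on it.

Compound 1 `O=C(Nc1cccc(CNc2nccnc2Cl)c1)Nc1ccccc1Cl` gives 6680 nM in a functional assay on T-24 cells (Homo sapiens) for antiproliferative activity, read by MTT assay, with a stated time of 48 h; a lower number here means a stronger inhibitor, a higher number a weaker inhibitor.
Compound 2 `O=C(Nc1cccc(CNc2nccnc2Cl)c1)Nc1ccc(Cl)cc1Br` gives 6650 nM in this assay.
Compound 3 `Cc1ccccc1NC(=O)Nc1cccc(CNc2nccnc2Cl)c1` gives 13600 nM in this assay.

All three share the same core and differ only in the phenyl attached to the urea nitrogen. Compound 3 has the highest number of the three, that is, it is the weakest inhibitor here: a 2.0-fold higher number from compound 1 to compound 3 (0.31 log units; beyond the scatter) and a 2.0-fold higher number from compound 2 to compound 3 (0.31 log units; beyond the scatter), both beyond the scatter, while a 1.0-fold lower number from compound 1 to compound 2 (0.00 log units; within the scatter), so compounds 1 and 2 cannot be told apart.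

Compound 4 `O=C(Nc1cccc(CNc2nccnc2Cl)c1)Nc1ccc(Cl)cc1Cl` is not yet measured. Its difference from compound 3 is 2,4-dichlorophenyl in place of 2-methylphenyl on an amide-type nitrogen. Going by the values given here, two measured steps bear on this. Going back from compound 3 to compound 1 undoes the methyl-for-chloro swap, and compound 2 carries a 4-chloro on the same phenyl without any shift relative to compound 1. Taken together, restoring a chloro in place of the methyl and adding a second chloro should bring the number back to the level of compounds 1 and 2.

Compound 4 is therefore expected at 6800 nM, within 3400 nM to 13600 nM, which means an estimated step of a 2.0-fold lower number from compound 3 to compound 4 (0.30 log units; within the scatter).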

Compound 4, half-maximal inhibitory concentration: 5740 nM
For compound 4 the middle estimate is 1.2-fold (0.07 log units) above the measured one, within the range that was stated.
By their numbers in this assay, from the lowest: compounds 4, 2 and 1 (each within the scatter of the next); then compound 3.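

At the phenyl on the urea nitrogen, this assay separates 2,4-dichlorophenyl from 2-methylphenyl, with a 2.4-fold lower number from compound 3 to compound 4 (0.37 log units; beyond the scatter), so compound 3 now stands apart from three compounds that carry halogens on this ring rather than from two. The steps among those three are small: chloro in place of bromo gives a 1.2-fold lower number from compound 2 to compound 4 (0.06 log units; within the scatter), and chloro in place of hydrogen gives a 1.2-fold lower number from compound 1 to compound 4 (0.07 log units; within the scatter), both within the scatter, so neither exchanging this halogen nor adding this second chloro can be seen in this read-out. Nothing measured here explains why the methyl-bearing ring differs from the halogen-bearing rings.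

The compounds shown leave open whether the methyl itself matters or only the loss of a halogen, and a ring bearing both a methyl and a chloro would be one way to separate the two. They also leave open how other groups on this phenyl would read, such as a methoxy, a nitrile, an amine or a carboxylic acid, and whether any of these would move the number further than the halogens do.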